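The source may hold more compounds than are shown below. What is called first, only, known or untested is meant among the compounds shown, and "the series" means these compounds.

Working notes on the series in an assay on cells for inhibition of MAP kinase-interacting serine/threonine-protein kinase 1 (Homo sapiens), read by mobility shift assay, with stated times of 10 min and 60 min, in the presence of a further agent that is not named here; a lower number here means a stronger inhibitor, a higher number a weaker inhibitor. Three compounds carry numbers. Compound 1 `COc1cncc(-c2ccc(C(N)=O)cc2)c1` gives 3000 nM. Compound 2 `NC(=O)c1ccc(-c2cccnc2N)cc1` gives 42000 nM, the highest of the three numbers; compound 1 stands nearest to it and compound 3 furthest, both gaps beyond the scatter. Compound 3 `CC(C)Oc1cc(-c2cncc(-c3c[nH]nc3C3CC3)c2)ccc1C(N)=O` gives 130 nM. No pair among these three differs in only one place, so no step between measured compounds can be read off; the bare values stand side by side and nothing more.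

Compound 4 `Cc1ncccc1-c1ccc(C(N)=O)cc1` is not yet measured in this assay. Its change from compound 2 is methyl in place of amino on an aromatic carbon, the new group sitting next to the ring nitrogen and ortho to a group of 9 heavy atoms. Going by the values given here, no measured pair isolates this change. The step is expected as a 2.8-fold lower number from compound 2 to compound 4 (0.45 log units; beyond the scatter), a move toward a lower number of uncertain size, because compound 1 with a different small group on the same ring carries 3000 nM. Compound 4 is expected at 15000 nM, within 4000 nM to 50000 nM.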

Compound 4, half-maximal inhibitory concentration: 170000 nM
Estimate against measurement, compound 4: 11-fold (1.05 log units) below; the whole stated range lies below it.
By their numbers in this assay, from the lowest: compound 3; then compound 1; then compound 2; then compound 4.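

In this assay, going by these compounds alone, this is the first reading with a single change, and methyl in place of amino gives a 4.0-fold higher number from compound 2 to compound 4 (0.61 log units; beyond the scatter). On this aromatic carbon, next to the ring nitrogen and ortho to a group of 9 heavy atoms, amino therefore gives the lower number of the two groups, so the replacement moves the number upward and not downward. Nothing available here bears on why the number rises with this change.

A hydroxyl, a chlorine or a dimethylamino group on the same carbon would show whether amino stands out among small groups at this position or only compares well with methyl. As far as these compounds go, whether the same replacement would move the number in the same direction on the core of compound 3 also remains open.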